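The source may report more compounds than this note shows. Statements on the series, on what has been measured and on what is new or still open speak of the compounds shown alone.

The measured compounds and their values:

compound 1, `CCC1Oc2c(Cl)cccc2N(O)C1=O`: 305000 nM
compound 2, `O=C1C(c2ccccc2)Oc2ccc(F)cc2N1O`: 1240000 nM
compound 3, `O=C1C(c2ccccc2)Oc2c(Cl)cccc2N1O`: 384000 nM

All three were tested in an ADME assay on the whole organism for inhibition, with Oryza sativa as the target, with a stated time of 7 days; a lower number here means a stronger inhibitor, a higher number a weaker inhibitor. Compound 3 and compound 1 share a core and differ in a single place: ethyl in place of phenyl on a saturated ring carbon. This change made a step of a 1.3-fold lower number from compound 3 to compound 1 (0.10 log units; within the scatter), so the two values are not distinguishable here. Compound 2 has a different core from compound 3; the difference between the two cores is not broken down here. Its value is the highest of the three, and the gaps to compound 3 and to compound 1 lie beyond the usual scatter, so compound 2 is the weakest inhibitor among the measured compounds.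

Compound 4, `CCC1Oc2ccc(F)cc2N(O)C1=O`, has not yet been measured. It stands to compound 2 as compound 1 stands to compound 3: ethyl in place of phenyl on a saturated ring carbon. The place is the same in both pairs, so this is the same change. Because the earlier step was a 1.3-fold lower number from compound 3 to compound 1 (0.10 log units; within the scatter), the step from compound 2 to compound 4 is expected to be small as well, about a 1.3-fold lower number from compound 2 to compound 4 (0.12 log units; within the scatter). Compound 4 is therefore estimated at 950000 nM, between 400000 nM and 2500000 nM.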

Compound 4, half-maximal inhibitory concentration: 15000 nM
Beside the measured number, compound 4's estimate is 63-fold (1.80 log units) above it; the whole stated range lies above it.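

In this assay, putting ethyl in place of phenyl on the saturated ring carbon had a large effect on one core, an 83-fold lower number from compound 2 to compound 4 (1.92 log units; beyond the scatter). The same swap on the other core gave no step that can be told from the scatter, so the size of this change did not carry from one core to the other: the same change on two cores in this assay, a 1.3-fold lower number (0.10 log units; within the scatter) from compound 3 to compound 1 and an 83-fold lower number (1.92 log units; beyond the scatter) from compound 2 to compound 4, 66-fold (1.82 log units) apart, beyond the scatter of two such steps

This shows that, in this series, a step measured on one core can be a poor guide to the step on another. It does not show which difference between the two cores sets the size of the step, and two pairs cannot say how the change would behave on a third core.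

Going by these compounds, only phenyl and ethyl appear at this carbon, so it remains open how a longer chain such as butyl, an amine or a carboxylic acid there would compare on either core. Also open, on these data alone, is the size of the step on a core with neither chlorine nor fluorine.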